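Chain extension at compound 3: notes on compound 4

The compounds below may be only part of what the source reports. "The series", "measured", "known", "first", "only" and "open" are said of these compounds alone.

Measured in a functional assay for activation of Alpha-1D adrenergic receptor (Homo sapiens); on this read-out higher numbers stand for an effect only at larger amounts of compound and lower numbers for an effect already at smaller amounts:
compound 1 `c1csc(-c2ccccc2NCC2=NCCN2)c1`: 18.2 nM
compound 2 `Cc1ccsc1-c1ccccc1NCC1=NCCN1`: 49 nM
compound 3 `CO/N=C(\C)c1ccccc1NCC1=NCCN1`: < 5020 nM (a limit of the assay)

Compound 3 stands only at a limit in this assay, the reading < 5020 nM being that limit and not a number (the limit of < 5020 nM in this assay, at which 1 of the 3 values shown sits). Compound 4 `CC/C(=N/OC)c1ccccc1NCC1=NCCN1` differs from compound 3 by a group of 6 heavy atoms (4 carbon, 1 nitrogen, 1 oxygen; no ring) in place of a group of 5 heavy atoms (3 carbon, 1 nitrogen, 1 oxygen; no ring), on an aromatic carbon. The steps leading into compound 3 are unreadable: a step that the limit leaves unreadable from compound 1 to compound 3 and a step that the limit leaves unreadable from compound 2 to compound 3. Going by the values given here, the single readable step in the set is the methyl in place of hydrogen, a 2.7-fold higher number from compound 1 to compound 2 (0.43 log units; beyond the scatter), a modest shift. A small change of similar kind is therefore expected to move compound 4 little, and compound 4 is estimated at 3000 nM with a range from 300 nM to 15000 nM. The expected step is a step that the limit leaves unreadable from compound 3 to compound 4, with considerable risk that only a limit is again reported.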

Compound 4, half-maximal effective concentration: < 5020 nM
Compound 4 was reported as a limit; the forecaster's own chance of this, stated with the estimate: 50%; the middle value is on the limit's open side.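

In this assay, going by these compounds alone, compound 4 reads < 5020 nM, a limit and not a number, so no step linking it to compound 1, compound 2 or compound 3 can be read. From the compounds shown here alone, whether compound 3 and compound 4 actually differ remains open.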